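Swapping the Aromatic Group on a Shared Core

This account rests on a few compounds, and the source may have more. Where it says the series, first, only, none or still open, it means among the compounds named here.

Compound 1 `COc1cc2ncnc(NNC(=S)NC(=O)c3ccc(Cl)cc3)c2cc1OC` gives 3710 nM in a functional assay on MGC-803 cells (Homo sapiens) for cytotoxicity, read by MTT assay, with a stated time of 72 h; a higher number here means a weaker inhibitor, a lower number a stronger inhibitor.
Compound 2 `COc1cc2ncnc(NNC(=S)NC(=O)c3ccc(C(F)(F)F)cc3)c2cc1OC` gives 9280 nM in this assay.

Within the data shown here, of the two numbers measured so far, compound 2 has the higher one, meaning it is the weaker of the pair; the step of a 2.5-fold higher number from compound 1 to compound 2 (0.40 log units; beyond the scatter) is modest but lies beyond the scatter. Compound 3 `COc1cc2ncnc(NNC(=S)NC(=O)c3ccccc3C)c2cc1OC` has not yet been measured. It differs from compound 2 in one place: 2-methylphenyl in place of 4-(trifluoromethyl)phenyl on a carbonyl carbon. Among the measured compounds shown here, the one measured step bears on this change only loosely, since it shows how much changing the group on this aromatic ring can shift the number, but not what a methyl group does. Without a direct comparison for 2-methylphenyl, the expectation is that compound 3 lands somewhere between the two measured values, with a wide margin of uncertainty. Compound 3 is therefore estimated at 5000 nM, with a plausible range from 1500 nM to 16000 nM. Relative to compound 2, this estimate means a step of a 1.9-fold lower number from compound 2 to compound 3 (0.27 log units; within the scatter), expected to be lower but not with confidence beyond the scatter.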

Compound 3, half-maximal inhibitory concentration: 11100 nM
Estimate against measurement, compound 3: 2.2-fold (0.35 log units) below; low and high end bracket the measured number.
By their numbers in this assay, from the lowest: compound 1; then compounds 2 and 3 (each within the scatter of the next).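

In this assay, 2-methylphenyl in place of 4-(trifluoromethyl)phenyl on the carbonyl carbon gives a 1.2-fold higher number from compound 2 to compound 3 (0.08 log units; within the scatter), so compound 2 and compound 3 cannot be told apart, although the two groups carry different substituents at differently numbered ring positions. Measured against the 4-chlorophenyl group, the same 2-methylphenyl group gives a 3.0-fold higher number from compound 1 to compound 3 (0.48 log units; beyond the scatter), a modest step but one beyond the scatter, which leaves compound 1 as the strongest of the three, with both of its steps beyond the scatter, and shows that a second replacement of its chloro-bearing group also gives a higher number. No accompanying measurement accounts for these numbers.

Going by these compounds, compound 3 changes both the substituent and its numbered ring position at once, so the effect of each alone stays open, and 4-methylphenyl or 2-chlorophenyl at this carbonyl carbon would be needed to separate them. Also open, on these data alone, is how unsubstituted phenyl, or a ring bearing an amine or a carboxylic acid, would compare with compound 1 in this assay.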